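Swapping Methoxy for Methylsulfonyl on the Amine Nitrogen

The compounds below may be only part of what the source reports. "The series", "measured", "known", "first", "only" and "open" are said of these compounds alone.

Three compounds of this series have been run through an in vivo ADME assay on the whole organism (strain Sprague-Dawley) for pharmacokinetics, with Rattus norvegicus as the target, at a dose of 5 mg/kg by the intravenous route; on this read-out lower numbers stand for slow clearance and higher numbers for fast clearance. Compound 1 `Cc1ccc(CNC2(CCC(C)(C)C)C(=O)C(C3=NS(=O)(=O)c4cc(NS(C)(=O)=O)ccc4N3)=C(O)c3ccccc32)cn1` gives 98.3 mL/min/kg in this assay. Compound 2 `CON[C@]1(CCC(C)C)C(=O)C(C2=NS(=O)(=O)c3cc(NS(C)(=O)=O)ccc3N2)=C(O)c2ccccc21` gives 45 mL/min/kg in this assay, the second highest of the three numbers; its nearest neighbour is compound 1, which lies higher by a margin beyond the scatter, and its furthest is compound 3 `Cc1cccc(C)c1CN[C@]1(CCC(C)(C)C)C(=O)C(C2=NS(=O)(=O)c3cc(NS(C)(=O)=O)ccc3N2)=C(O)c2ccccc21`, which in this assay gives 11.7 mL/min/kg, lower than compound 2 by a margin beyond the scatter.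

The unmeasured compound 4 `CC(C)CC[C@@]1(NS(C)(=O)=O)C(=O)C(C2=NS(=O)(=O)c3cc(NS(C)(=O)=O)ccc3N2)=C(O)c2ccccc21` departs from compound 2 in one place: methylsulfonyl in place of methoxy on an amine nitrogen. Among the compounds with values here, none of the measured pairs differs by this change alone, so the measured set offers no step of this kind to lean on. The step from compound 2 to compound 4 is therefore expected to be modest, most likely within the scatter, with no direction favoured: a 1.1-fold lower number from compound 2 to compound 4 (0.05 log units; within the scatter). On that basis compound 4 is estimated to give 40 mL/min/kg in this assay, within a range from 15 mL/min/kg to 100 mL/min/kg.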

Compound 4, clearance: 71.7 mL/min/kg
Beside the measured number, compound 4's estimate is 1.8-fold (0.25 log units) below it, within the range that was stated.
By their numbers in this assay, from the lowest: compound 3; then compounds 2, 4 and 1 (each within the scatter of the next, the first and the last beyond it).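

Within the data shown here, the step of a 1.6-fold higher number from compound 2 to compound 4 (0.20 log units; within the scatter) is the first reading in this assay of a single change on this amine nitrogen, since no earlier pair of compounds differed in one place only. It shows that methylsulfonyl can replace methoxy there, bringing in a larger group with a sulfur atom, without moving clearance beyond the usual scatter. On this read-out the two groups cannot be told apart at this position. Nothing shown here bears on the reason for this result.

From the compounds shown here alone, it remains open whether a group such as acetyl, or an unsubstituted amine, on the same nitrogen would give a step beyond the scatter. Going by these compounds, it is also open whether the same swap would read alike with a longer chain elsewhere on the shared core.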